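The source may report more compounds than this note shows. Statements on the series, on what has been measured and on what is new or still open speak of the compounds shown alone.

Compound 1 (`O=C1/C(=C/c2cccnc2)CN(S(=O)(=O)c2ccccc2)C/C1=C\c1ccccc1F`) gives 19100 nM in a functional assay on SMMC-7721 cells (Homo sapiens) for cytotoxicity, read by MTT assay, with a stated time of 24 h (a higher number here means a weaker inhibitor, a lower number a stronger inhibitor), and compound 2 (`O=C1/C(=C/c2cccnc2)CN(S(=O)(=O)c2ccc(F)cc2)C/C1=C\c1ccccc1F`) gives 9900 nM there, so the two lie within the scatter of each other. Compound 3 (`O=C1/C(=C/c2ccncc2)CN(S(=O)(=O)c2ccccc2)C/C1=C\c1ccccc1F`) carries pyridin-4-yl in place of pyridin-3-yl on a double-bonded chain carbon bound to a double-bonded ring carbon. Going by the values given here, the only measured step (a 1.9-fold lower number from compound 1 to compound 2 (0.29 log units; within the scatter)) is a different change, fluoro in place of hydrogen on an aromatic carbon, and it gives no size for this swap. In this assay no step beyond the scatter is therefore expected in either direction. The estimated step (a 1.3-fold lower number from compound 1 to compound 3 (0.10 log units; within the scatter)) is correspondingly small. For compound 3 the estimate is 15000 nM with an expected range from 6000 nM to 40000 nM in this measurement.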

Compound 3, half-maximal inhibitory concentration: 17500 nM
Compound 3: the middle estimate sits 1.2-fold (0.07 log units) below what was measured; low and high end bracket the measured number.
By their numbers in this assay, from the lowest: compounds 2, 3 and 1 (each within the scatter of the next).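

On the double-bonded chain carbon bound to a double-bonded ring carbon, pyridin-4-yl in place of pyridin-3-yl gives a 1.1-fold lower number from compound 1 to compound 3 (0.04 log units; within the scatter) in this assay, so this swap leaves the number within the scatter. It is the only step shown at this position, and it gives the position its first measured size. No available evidence bears on this result. Going by these compounds, whether pyridin-2-yl or a phenyl ring carrying an amine or a carboxylic acid at this place would give a step beyond the scatter remains open. On these data alone, it is also open whether pyridin-4-yl gives a step of similar size alongside the fluoro of compound 2.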